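A few compounds are considered here, and "the series" means these few. Any claim that something is new, unique, unknown or untested is made for them only; others in the source may bear on it.

Compound 1 `CC(C)N(CCN(C(=O)Nc1ccc(F)c(Cl)c1)C1CC[C@]2(c3cccc(C#N)c3)CC2C1)C(C)C`, measured in a functional assay for antagonist activity at melanin-concentrating hormone receptor 1 (Homo sapiens); a lower number here means a stronger inhibitor, a higher number a weaker inhibitor: 4.98 nM.
Compound 2 `CC(C)N(CCN(C(=O)Nc1cccc(C#N)c1)C1CC[C@]2(c3cccc(C#N)c3)CC2C1)C(C)C`: 7.6 nM.
Compound 3 `N#Cc1cccc([C@]23CCC(N(CCN4CCCC(O)C4)C(=O)Nc4ccc(F)c(Cl)c4)CC2C3)c1`: 22 nM.

Among these three, compound 1 shows the lowest number in this assay. Its nearest neighbour is compound 2, reached by a 1.5-fold higher number from compound 1 to compound 2 (0.18 log units; within the scatter), a step that stays within the scatter. The furthest is compound 3, reached by a 4.4-fold higher number from compound 1 to compound 3 (0.65 log units; beyond the scatter), a modest loss that lies beyond the scatter.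

Compound 4 `CCN(CC)Cc1cccc([C@]23CCC(N(CCN(C(C)C)C(C)C)C(=O)Nc4ccc(F)c(Cl)c4)CC2C3)c1` keeps the shared core of compound 1 and differs from it only at the aromatic ring attached to that core: (diethylamino)methyl in place of cyano on an aromatic carbon. Neither measured step bears directly on this position. The step from compound 1 to compound 2 alters the aryl group on the amide-type nitrogen and changes little; the step from compound 1 to compound 3 alters the amine on the saturated chain and costs a modest amount. The aryl group on the core itself has not been varied among the measured compounds, so any expectation here rests on thin ground. A step of modest size in either direction, or none beyond the scatter, is plausible; the estimate for compound 4 is therefore set close to compound 1 with a wide range.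

Compound 4 is expected to give 10 nM in this assay, within a range of 2.5 nM to 40 nM. This estimate for compound 4 amounts to an expected step of a 2.0-fold higher number from compound 1 to compound 4 (0.30 log units; within the scatter).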

Compound 4, inhibition constant: 46 nM
Compound 4: middle estimate off by 4.6-fold (0.66 log units), on the low side; the whole stated range lies below it.
By their numbers in this assay, from the lowest: compounds 1 and 2 (each within the scatter of the next); then compound 3; then compound 4.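

Compound 4 is the only compound here that varies the aromatic ring attached to the shared core, and in this assay exchanging cyano for (diethylamino)methyl on that aromatic carbon gives a 9.2-fold higher number from compound 1 to compound 4 (0.97 log units; beyond the scatter) as the largest of the steps shown from compound 1. This position therefore responds to substitution more than the earlier changes could indicate, with the step here exceeding both the step at the aryl group on the amide-type nitrogen and the step at the amine on the saturated chain. The larger group brings more heavy atoms while the counts of hydrogen-bond donors and acceptors stay the same, but no measurement shown explains why this exchange raises the number.

The compounds shown do not separate the contribution of the diethylamino group from that of the methylene linking it to the ring, which a plain methyl group or a smaller dimethylaminomethyl group on the same aromatic carbon could address. On these data alone, it also remains open whether a non-amine replacement for cyano, such as a methoxy group or a chlorine atom, would be tolerated at this position.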